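A few compounds are considered here, and "the series" means these few. Any claim that something is new, unique, unknown or untested is made for them only; others in the source may bear on it.

Compound 3 `CCOc1ccc(-n2nncc2CN2C(=O)C3(C(C#N)=C(N)Oc4c(N)cc5nc6ccccc6nc5c43)c3ccccc32)cc1` stands at the weak end of what this study can resolve: in a functional assay on HCT-116 cells (Homo sapiens) for antiproliferative activity, read by MTT assay, with a stated time of 48 h (a higher number here means a weaker inhibitor, a lower number a stronger inhibitor), compound 3 gives > 50000 nM, which is a limit of the assay rather than a measured number. Compound 1 `N#CC1=C(N)Oc2c(N)cc3nc4ccccc4nc3c2C12C(=O)N(Cc1cnnn1-c1ccc(Cl)cc1)c1ccccc12` also gives only a limit, > 50000 nM. Compound 2 `N#CC1=C(N)Oc2c(N)cc3nc4ccccc4nc3c2C12C(=O)N(Cc1cnnn1-c1cccc(Br)c1)c1ccccc12` gives a real number, 26100 nM. The readable steps therefore all run through compound 2: an at least 1.9-fold lower number from compound 1 to compound 2 (0.28 log units; that floor lies within the scatter), and an at least 1.9-fold higher number from compound 2 to compound 3 (0.28 log units; that floor lies within the scatter). The step that the two limits leave unreadable from compound 1 to compound 3 cannot be read at all, since both of its ends sit at the limit of > 50000 nM in this assay, at which 2 of the 3 values shown sit. Compound 4 `N#CC1=C(N)Oc2c(N)cc3nc4ccccc4nc3c2C12C(=O)N(Cc1cnnn1-c1c(F)cccc1F)c1ccccc12` differs from compound 3 in one place: 2,6-difluorophenyl in place of 4-ethoxyphenyl on an aromatic nitrogen. Both swaps of the group on that aromatic nitrogen that were measured stayed within the scatter, so no large movement is expected from this third swap either. Compound 4 is expected to give about 45000 nM, with a range from 15000 nM to 150000 nM. The expected step of an at least 1.1-fold lower number from compound 3 to compound 4 (0.04 log units; that floor lies within the scatter) is thus small, and a further limit is more likely than not.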

Compound 4, half-maximal inhibitory concentration: > 50000 nM
Compound 4: only a limit was reported; the forecaster's own chance of this, stated with the estimate: 60%; middle value at least 1.1-fold (0.04 log units) from the limit.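

Across the aromatic nitrogen, the 4-chlorophenyl of compound 1, the 4-ethoxyphenyl of compound 3 and now the 2,6-difluorophenyl of compound 4 all end at the same limit in this assay, and only the 3-bromophenyl of compound 2 gives a real number: the limit of > 50000 nM in this assay, at which 3 of the 4 values shown sit. Among the compounds shown here, the one readable new step is an at least 1.9-fold higher number from compound 2 to compound 4 (0.28 log units; that floor lies within the scatter), so the true size of this change remains unknown. The steps to compound 4 from compound 1 and from compound 3 cannot be read, as both ends of each are limits.

All four groups shown on this nitrogen are substituted phenyl rings, so it stays open whether any group can bring the number well under that of compound 2, 26100 nM. The compounds shown say nothing about an amine or a carboxylic acid on that phenyl ring, or about a longer chain in its place.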